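A few compounds are considered here, and "the series" means these few. Any claim that something is new, unique, unknown or untested is made for them only; others in the source may bear on it.

Working notes on the series. Within the data shown here, compound 3 is `NCc1cccc(CN(C[C@H]2Cc3ccccc3CN2)[C@H]2CCCc3cccnc32)c1`; in a functional assay on cells for antagonist activity at C-X-C chemokine receptor type 4 (Homo sapiens), read by fluorescence and calcium flux, with stated times of 25 min and 90 s (a lower number here means a stronger inhibitor, a higher number a weaker inhibitor), compound 3 gives 292 nM, the highest number of the three measured so far. Compound 1, `c1ccc2c(c1)CN[C@@H](CN(CCCCNCc1ccncc1)[C@H]1CCCc3cccnc31)C2`, gives 22.7 nM, and compound 2, `c1ccc2c(c1)CN[C@@H](CN(CCCCNCC1CCOCC1)[C@H]1CCCc3cccnc31)C2`, gives 52.9 nM. Both steps onto compound 3 run the same way: a 13-fold higher number from compound 1 to compound 3 (1.11 log units; beyond the scatter) and a 5.5-fold higher number from compound 2 to compound 3 (0.74 log units; beyond the scatter), whereas the step between the two chain-bearing compounds, a 2.3-fold higher number from compound 1 to compound 2 (0.37 log units; beyond the scatter), is smaller.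

Compound 4 is `C(=C/CN(C[C@H]1Cc2ccccc2CN1)[C@H]1CCCc2cccnc21)\CNCc1ccccn1`. It differs from compound 3 thus: a group of 11 heavy atoms (9 carbon, 2 nitrogen; one six-membered aromatic ring with 1 hetero atom) in place of a group of 8 heavy atoms (7 carbon, 1 nitrogen; one six-membered aromatic ring of carbon only), on a saturated chain carbon bound to an amine nitrogen. The entering group is again a chain ending in an amine carrying a pyridine, closer in make-up to the chains of compound 1 and compound 2 than to the group of compound 3, so the steps onto compound 3 bear directly on this change and are expected to run back in the opposite direction. A step of roughly the size seen from compound 2 to compound 3, reversed, is expected, with the double bond and the changed pyridine attachment left open. Compound 4 is therefore expected to give 45 nM, range 12 nM to 150 nM, an estimated step of a 6.5-fold lower number from compound 3 to compound 4 (0.81 log units; beyond the scatter).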

Compound 4, half-maximal inhibitory concentration: 58.3 nM
Compound 4: the middle estimate sits 1.3-fold (0.11 log units) below what was measured, within the range that was stated.
By their numbers in this assay, from the lowest: compound 1; then compounds 2 and 4 (each within the scatter of the next); then compound 3.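

At this position, on a saturated chain carbon bound to an amine nitrogen, a third chain ending in an amine carrying a ring separates from the 3-(aminomethyl)phenyl group of compound 3 in this assay (a 5.0-fold lower number from compound 3 to compound 4 (0.70 log units; beyond the scatter)). The group of compound 4 does not separate from the oxan-4-yl chain of compound 2 (a 1.1-fold higher number from compound 2 to compound 4 (0.04 log units; within the scatter)), yet it does separate from the group of compound 1 (a 2.6-fold higher number from compound 1 to compound 4 (0.41 log units; beyond the scatter)), so equal heavy-atom make-up does not give equal numbers here. No evidence on hand accounts for these differences.

Going by these compounds, compound 4 differs from compound 1 in both the double bond and the pyridine attachment, so the share of each in that step remains open. A saturated chain ending in pyridin-2-yl would separate the two, and a pyridin-3-yl end group or a longer chain would test how far the position tolerates change.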